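A methoxy group added to compound 2

This account rests on a few compounds, and the source may have more. Where it says the series, first, only, none or still open, it means among the compounds named here.

So far a functional assay on MCF7 cells (Homo sapiens) for inhibition, read by MTT assay (on this read-out higher numbers stand for weaker inhibition and lower numbers for stronger inhibition), has given numbers for two compounds. Compound 1 (`Cc1ccc(-c2nnc(NC(=O)CCCCCCC(=O)NO)s2)o1`) reads 880 nM on this measure. Compound 2 (`O=C(COc1ccc(C(=O)/C=C/c2ccccc2)cc1)NO`) reads 620 nM on the same measure. The gap between these two lies within the usual scatter of repeated measurements, so compound 2 stands level with compound 1 and neither can be ranked over the other.

Compound 3 (`COc1ccc(/C=C/C(=O)c2ccc(OCC(=O)NO)cc2)cc1`) has not been measured yet. It is compound 2 with one change (methoxy in place of hydrogen on an aromatic carbon) in which methoxy takes the place of hydrogen on an aromatic carbon, para to a large group, turning phenyl to 4-methoxyphenyl. Among the measured compounds shown here, no pair of measured compounds shows what a swap like this does, so the expectation rests on the structural change alone. The change is small, and no step beyond the scatter is expected in this assay in either direction. The estimate amounts to a 1.1-fold lower number from compound 2 to compound 3 (0.05 log units; within the scatter) as an expected step that stays within the scatter. Compound 3 is estimated at 550 nM within an expected range of 200 nM to 1500 nM on this read-out.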

Compound 3, half-maximal inhibitory concentration: 620 nM
Compound 3: the middle estimate sits 1.1-fold (0.05 log units) below what was measured, and the stated range covers the measured number.
By their numbers in this assay, from the lowest: compounds 2, 3 and 1 (each within the scatter of the next).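

In this assay, among the compounds shown here, putting methoxy in place of hydrogen on an aromatic carbon, para to a large group, gives no change at the digits printed from compound 2 to compound 3 (within the scatter), and this is the first step here that isolates a single change. It shows that at this position, turning phenyl to 4-methoxyphenyl adds 2 heavy atoms and a hydrogen-bond acceptor without moving the read-out beyond the usual variation between repeated measurements. No other measurement bears on this result, so the data cannot say why the number holds steady.

One substituent at one position cannot show how far this flat response extends, since a hydroxyl, an amine, a carboxylic acid or a longer chain such as ethoxy at the same carbon could give a different answer. Going by these compounds, it also remains open whether methoxy on another carbon of this ring, or on the other aromatic ring of the core, would behave the same way in this assay.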